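Shifting a fluoropyridine ring in a compound series

The source may hold more compounds than are shown below. What is called first, only, known or untested is meant among the compounds shown, and "the series" means these compounds.

Measured in an ADME assay on the whole organism (plasma, Rattus norvegicus) for protein binding, using cassette dosing, at a dose of 1 mg/kg; a lower number here means a smaller unbound share, a higher number a larger unbound share of the compound:
- compound 1 `C[C@@H](Cn1c(=O)[nH]/c(=N\c2ccc(Oc3ccc(F)cn3)cc2)n(Cc2ccc(Cl)cc2)c1=O)C(=O)O` gives 0.011
- compound 2 `C[C@@H](Cn1c(=O)[nH]/c(=N\c2ccc(Oc3cnccn3)cc2)n(Cc2ccc(Cl)cc2)c1=O)C(=O)O` gives 0.018
- compound 3 `C[C@@H](Cn1c(=O)[nH]/c(=N\c2ccc(Oc3cccc(F)n3)cc2)n(Cc2ccc(Cl)cc2)c1=O)C(=O)O` gives 0.007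

Compound 3 (0.007) cannot be separated from compound 1 on these numbers and stands clearly apart only from compound 2. Compound 4 `C[C@@H](Cn1c(=O)[nH]/c(=N\c2ccc(Oc3ccnc(F)c3)cc2)n(Cc2ccc(Cl)cc2)c1=O)C(=O)O` has the same atoms as compound 3, joined differently: 2-fluoropyridin-4-yl in place of 6-fluoropyridin-2-yl on an oxygen on an aromatic ring. In words, 2-fluoropyridin-4-yl sits in place of 6-fluoropyridin-2-yl on an oxygen on an aromatic ring.

For the measured compounds named here, no measured step covers this exact change. The closest is the swap between two fluoropyridines, a 1.6-fold lower number from compound 1 to compound 3 (0.20 log units; within the scatter), which is small. Replacing the fluoropyridine with pyrazin-2-yl gave a 1.6-fold higher number from compound 1 to compound 2 (0.21 log units; within the scatter), also small. Going by the values given here, only one step exceeds the scatter, and modestly: a 2.6-fold lower number from compound 2 to compound 3 (0.41 log units; beyond the scatter). A further swap of this ring is therefore not expected to move this assay beyond the scatter, and the estimated change is a 1.4-fold higher number from compound 3 to compound 4 (0.15 log units; within the scatter). Compound 4 is expected at 0.01 (estimated range 0.005 to 0.02).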

Compound 4, unbound fraction: 0.013
For compound 4 the middle estimate is 1.3-fold (0.11 log units) below the measured one; the range from low to high includes it.
By their numbers in this assay, from the lowest: compounds 3, 1, 4 and 2 (each within the scatter of the next, the first and the last beyond it).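

Swapping 6-fluoropyridin-2-yl for 2-fluoropyridin-4-yl, which keeps the same atoms but joins them differently, gives a step in this assay that stays within the scatter (a 1.9-fold higher number from compound 3 to compound 4 (0.27 log units; within the scatter)), so this rearrangement of the ring on the oxygen has no effect that can be told apart here. Compound 4 also lies within the scatter of both other compounds (a 1.2-fold higher number from compound 1 to compound 4 (0.07 log units; within the scatter) and a 1.4-fold lower number from compound 2 to compound 4 (0.14 log units; within the scatter)), so unlike compound 3, which stands clearly apart from compound 2, it cannot be separated from any compound in the set. Nothing available here explains how these rings compare in this measurement. From the compounds shown here alone, whether a methoxy group or an amine in place of the fluorine would move the unbound fraction beyond the scatter remains open. Also open, going by these compounds, is whether an amide in place of the carboxylic acid would do so.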